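The source may hold more compounds than are shown below. What is called first, only, known or untested is meant among the compounds shown, and "the series" means these compounds.

In a functional assay on HT-22 cells (Mus musculus), read by LDH release (a lower number here means that less compound is tolerated, a higher number that more compound is tolerated), compound 1 (`CC1(C)Nc2c(ccc(C(=O)c3ccccc3)c2O)OC1NC1CCCCC1`) gives 120 uM. Compound 2 (`CC1(C)Nc2c(ccc(C(=O)c3ccccc3)c2O)OC1N1CCCCC1`) gives 120 uM. Compound 3 (`CN(CC1OCCO1)C1Oc2ccc(C(=O)c3ccccc3)c(O)c2NC1c1ccccc1`) stands at > 250 uM, which is a limit of the assay and not a number. Compound 4 (`COC(CNC1Oc2ccc(C(=O)c3ccccc3)c(O)c2NC1c1ccccc1)OC`) carries (2,2-dimethoxyethyl)amino in place of ((1,3-dioxolan-2-yl)methyl)(methyl)amino on a saturated ring carbon. Among the compounds with values here, the only measured step that bears on this is also an exchange of amino groups on a saturated ring carbon, and it shows no change at the digits printed from compound 1 to compound 2 (within the scatter). On that basis, no step beyond the scatter is expected in this assay, in either direction, and the expected step is a number no higher from compound 3 to compound 4 (the limit leaves the size open). The estimate for compound 4 is 250 uM, with an expected range from 130 uM to 500 uM.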

Compound 4, half-maximal toxic concentration: > 250 uM
Compound 4 ended at the assay's limit; the forecaster's own chance of this, stated with the estimate: 55%; the middle value lies on the limit itself.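

No step can be read between compound 3 and compound 4, since both results are limits of the assay and not numbers: the limit of > 250 uM in this assay, at which 2 of the 4 values shown sit.

The compounds shown leave open whether this exchange of amino groups on a saturated ring carbon changes the tolerated concentration at all.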